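Methyl in Place of Bromo Where Three Compounds Sit at a Limit

The source may hold more compounds than are shown below. What is called first, only, known or untested is meant among the compounds shown, and "the series" means these compounds.

Three compounds share one core and differ only in the ring carried on the aromatic nitrogen. Compound 1 `Fc1cccc(-c2nc(Nc3cccc(Cl)c3)c3cc(F)ccc3n2)c1` was tested in a functional assay on U2OS cells (Homo sapiens) for cytotoxicity, read by MTT assay, with a stated time of 48 h (a lower number here means a stronger inhibitor, a higher number a weaker inhibitor), and there compound 1 gives only a limit of the assay, > 50000 nM. Compound 2 `Fc1cccc(-c2nc(Nc3ccccc3Cl)c3cc(F)ccc3n2)c1` in this assay likewise gives a limit, > 50000 nM. Compound 3 `Fc1cccc(-c2nc(Nc3ccccc3Br)c3cc(F)ccc3n2)c1` in this assay also stands at a limit, > 50000 nM. The steps a step that the two limits leave unreadable from compound 1 to compound 2, a step that the two limits leave unreadable from compound 1 to compound 3 and a step that the two limits leave unreadable from compound 2 to compound 3 cannot be sized because of the limit of > 50000 nM in this assay, at which 3 of the 3 values shown sit.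

Compound 4 `Cc1ccccc1Nc1nc(-c2cccc(F)c2)nc2ccc(F)cc12` has not yet been measured in this assay. It differs from compound 3 by methyl in place of bromo on an aromatic carbon. For the measured compounds named here, the one measured step that touches the same carbon, a step that the two limits leave unreadable from compound 2 to compound 3, gives no readable size, so the data offer neither a direction nor a magnitude for the new exchange. With every shown value at a limit, compound 4 is expected to stay there as well, and the step that the limit leaves unreadable from compound 3 to compound 4 is expected to be unreadable in the same way. The estimate for compound 4 in this assay is 70000 nM, ranging from 20000 nM to 300000 nM.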

Compound 4, half-maximal inhibitory concentration: > 50000 nM
Compound 4 gave a limit, no number (the forecaster's own chance of this, stated with the estimate: 80%); the middle value lies beyond the limit too.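

In this assay compound 4 gives > 50000 nM as a limit and not a number. For the compounds shown here, no step from compound 1, compound 2 or compound 3 to compound 4 can therefore be read: the limit of > 50000 nM in this assay, at which 4 of the 4 values shown sit.

The compounds shown leave open whether these four differ in this assay at all.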